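Methoxy to hydroxy on a bis-amidine core: cytotoxicity on L6 cells

This account rests on a few compounds, and the source may have more. Where it says the series, first, only, none or still open, it means among the compounds named here.

Measured compounds:
compound 1, `COc1cc(C(=N)NC(C)C)cc2cc(-c3ccc(C(=N)NC(C)C)cc3)oc12`, in an ADME assay on L6 cells (Rattus norvegicus) for cytotoxicity (on this read-out lower numbers stand for stronger inhibition and higher numbers for weaker inhibition), gives > 190000 nM, which is a limit of the assay rather than a number.
Compound 2, `CC(C)NC(=N)c1ccc(-c2cc3cc(C(=N)NC(C)C)cc(O)c3o2)cc1`, gives in this assay > 185000 nM, likewise a limit.
Among the compounds with values here, compound 3, `COc1cc(C2=NCCN2)ccc1-c1cc2ccc(C3=NCCN3)cc2o1`, gives in this assay 4400 nM, the only number among the three.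

Compound 4, `Oc1cc(C2=NCCN2)ccc1-c1cc2ccc(C3=NCCN3)cc2o1`, has not been measured in this assay. It differs from compound 3 by hydrogen in place of methyl on an oxygen on an aromatic ring, and the same change separates compound 1 from compound 2: hydrogen in place of methyl on an oxygen on an aromatic ring. The difference between the two cores of compound 1 and compound 3 is not broken down here. The measured instance of the change, a step that the two limits leave unreadable from compound 1 to compound 2, cannot be read because both ends sit at limits, the limit of > 190000 nM in this assay, at which 1 of the 3 values shown sits, and (the limit of > 185000 nM in this assay, at which 1 of the 3 values shown sits). Nothing among the compounds shown therefore points in either direction for this change. Within the data shown here, for compound 4 a step of a 1.4-fold higher number from compound 3 to compound 4 (0.13 log units; within the scatter) in this assay is expected, a small one lying within the usual scatter, because the only measured example, a step that the two limits leave unreadable from compound 1 to compound 2, gives no readable size. The estimate for compound 4 in this assay is 6000 nM, expected to fall between 2000 nM and 20000 nM.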

Compound 4, half-maximal inhibitory concentration: > 193000 nM
Compound 4 ended at the assay's limit; the forecaster's own chance of this, stated with the estimate: 5%; at least 32-fold (1.50 log units) between middle value and limit.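

On the core of compound 3, methoxy to hydroxy gives an at least 43-fold higher number from compound 3 to compound 4 (1.64 log units; beyond the scatter) in this assay, so on this core the change goes with much weaker inhibition on this read-out. The value of compound 4 is a limit of the assay and not a number: the limit of > 193000 nM in this assay, at which 1 of the 4 values shown sits. The same change on the core of compound 1 cannot be read, with both of its ends at limits, so the compounds shown do not tell whether the step carries from one core to the other: one core gives a large step and the other gives no readable step at all.

From the compounds shown here alone, it remains open what methoxy to hydroxy does on the core of compound 1 when both ends give numbers rather than limits. Going by these compounds, it is also open whether another group on that oxygen or in its stead, such as ethoxy or an amine, would stay close to compound 3 or move as far as hydroxy does.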